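The source may hold more compounds than are shown below. What is called first, only, known or untested is meant among the compounds shown, and "the series" means these compounds.

Compound 2 `COc1ccc(OC)c(-c2cc(-c3ccc(C(=O)NCC4CC4)s3)on2)c1` carries (cyclopropylmethyl)amino on the carbonyl carbon. In a functional assay on PC-3 cells (Homo sapiens) for cytotoxicity, read by XTT assay, with a stated time of 72 h (on this read-out lower numbers stand for stronger inhibition and higher numbers for weaker inhibition), compound 2 gives > 30000 nM, which is a limit of the assay and not a number. Compound 1 `CCN(CC)C(=O)c1ccc(-c2cc(-c3cc(OC)ccc3OC)no2)s1` also sits at a limit: in this assay compound 1 gives > 30000 nM. The step that the two limits leave unreadable from compound 1 to compound 2 therefore cannot be read. Compound 3 `COc1ccc(OC)c(-c2cc(-c3ccc(C(=O)N(C)Cc4ccccc4)s3)on2)c1` alters the amide: benzyl(methyl)amino in place of (cyclopropylmethyl)amino on a carbonyl carbon. No readable measured step bears on this change; both values shown sit at the limit of > 30000 nM in this assay, at which 2 of the 2 values shown sit. For compound 3 the expected step is a step that the limit leaves unreadable from compound 2 to compound 3, with no direction readable from the data. Compound 3 is estimated at 40000 nM, range 15000 nM to 120000 nM, most likely reported again as a limit.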

Compound 3, half-maximal inhibitory concentration: > 30000 nM
Compound 3: a limit, no number (the forecaster's own chance of this, stated with the estimate: 75%); the middle value lies beyond the limit too.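

No step can be read among compound 1, compound 2 and compound 3 in this assay; all three stand at a limit, not a number: the limit of > 30000 nM in this assay, at which 3 of the 3 values shown sit.

From the compounds shown here alone, how far the three amides differ from one another in this assay stays open.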